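Closing the Side Group into a Ring on a Shared Core

This account rests on a few compounds, and the source may have more. Where it says the series, first, only, none or still open, it means among the compounds named here.

Measured so far:
Compound 1 `CC/N=C(/N)Nc1nc(-c2ccc(OC)cc2)c(-c2ccc(OC)cc2)s1` gives > 100 nM in a functional assay with Oryctolagus cuniculus as the target; on this read-out lower numbers stand for stronger inhibition and higher numbers for weaker inhibition.
Compound 2 `CCN(CC)C(=O)c1nc(-c2ccc(OC)cc2)c(-c2ccc(OC)cc2)s1` gives < 10 nM in this assay.

Both of these values are limits of the assay rather than numbers. Compound 1 sits at the limit of > 100 nM in this assay, at which 1 of the 2 values shown sits. Compound 2 sits at the limit of < 10 nM in this assay, at which 1 of the 2 values shown sits, so it stands at the strong end of what the assay can resolve, with no exact number attached.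

Compound 3 `COc1ccc(-c2nc(C3=NNC(=O)CC3)sc2-c2ccc(OC)cc2)cc1` has not yet been measured. It differs from compound 2 in one place: a group of 7 heavy atoms (4 carbon, 2 nitrogen, 1 oxygen; one six-membered non-aromatic ring with 2 hetero atoms) in place of a group of 7 heavy atoms (5 carbon, 1 nitrogen, 1 oxygen; no ring), on an aromatic carbon. Going by the values given here, the only measured step touches the same place on the shared core: an at least 10-fold lower number from compound 1 to compound 2 (1.00 log units; beyond the scatter). Among the compounds with values here, that step shows that exchanging the group here can move the number by a large amount, yet neither compound 1 nor compound 2 carries a ring at that place, so the entering group has no measured counterpart. Because compound 2 sits at the limit of < 10 nM in this assay, at which 1 of the 2 values shown sits, the size of any step from it cannot be read exactly from the numbers shown.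

Compound 3 is therefore estimated at 15 nM, expected to fall between 3 nM and 80 nM in this assay. That estimate means an expected at least 1.5-fold higher number from compound 2 to compound 3 (0.17 log units; that floor lies within the scatter).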

Compound 3, half-maximal inhibitory concentration: > 1000 nM
Compound 3 gave a limit, no number (the forecaster's own chance of this, stated with the estimate: 30%); middle value at least 66-fold (1.82 log units) from the limit.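

In this assay, the new step is an at least 100-fold higher number from compound 2 to compound 3 (2.00 log units; beyond the scatter). Going by these compounds alone, the earlier step showed only that exchanging the group on this aromatic carbon can lower the number; this one shows that it can also raise it sharply, even though the diethylcarbamoyl group and the ring that replaces it have the same count of heavy atoms, so that count alone does not settle the outcome for these compounds. The result for compound 3 is a limit of the assay and not a number, and the step between compound 1 and compound 3 cannot be read, so the true size of the weakening remains unknown: the limit of > 1000 nM in this assay, at which 1 of the 3 values shown sits.

Going by these compounds, what stays open is which difference goes with the weaker result, since the entering group brings a ring, a second ring-bound nitrogen and a hydrogen-bond donor all at once. A pyrrolidine amide, which ties the two ethyl chains into a ring while keeping the carbonyl on the aromatic carbon, would help separate ring closure from those other differences.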